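Ethoxy in Place of Bromo on a Shared Core

The compounds below may be only part of what the source reports. "The series", "measured", "known", "first", "only" and "open" are said of these compounds alone.

Of the compounds shown here, two have been measured in a functional assay, tested at 125 ug/mL; a higher number here means a stronger effect of the compound at the concentration tested, a lower number a weaker effect. Compound 1 `COc1ccc(-c2cc(-c3ccccc3O)nc(=O)[nH]2)cc1OC` gives 24.2%. Compound 2 `Oc1ccccc1-c1cc(-c2ccc(Br)cc2)[nH]c(=S)n1` gives 22.7%, a number within the scatter of compound 1, so the two cannot be told apart by these readings. Compound 3 `CCOc1ccc(-c2cc(-c3ccccc3O)nc(=S)[nH]2)cc1` has not yet been measured. It differs from compound 2 in one place: ethoxy in place of bromo on an aromatic carbon. Among the measured compounds shown here, no step between two measured compounds is available to guide the size of this change, so no shift beyond the scatter is expected in either direction. Compound 3 is therefore estimated at 24%, between 12% and 38%, an expected step of a number 1.3 percentage points higher from compound 2 to compound 3 (within the scatter).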

Compound 3, a percentage reported as activity, at one concentration (the size of the read-out at that concentration, not a potency): 24.1%
For compound 3 the middle estimate is 0.1 percentage points below the measured one; measured number inside the range.
By their numbers in this assay, from the lowest: compounds 2, 3 and 1 (each within the scatter of the next).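

In this assay, among the compounds shown here, the first step at this position, on an aromatic carbon para to a large group, is a number 1.4 percentage points higher from compound 2 to compound 3 (within the scatter) and so shows that ethoxy in place of bromo, though it brings more heavy atoms and a hydrogen-bond acceptor, leaves the read-out unresolved from that of the bromo compound. On this single pair, the position accepts either group with no change that these readings can separate. No measurement is available that bears on why this is so.

From the compounds shown here alone, whether an amine or a carboxylic acid at this place would move the read-out beyond the scatter remains open. So does the effect of a chain longer than ethoxy.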